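The compounds below may be only part of what the source reports. "The series", "measured", "known", "first", "only" and "open" are said of these compounds alone.

Compound 1 `Cc1cc(NC(=O)Nc2ccc(C(C)(C)C)cc2)c2ccccc2n1` and compound 2 `CSc1ccc(NC(=O)Nc2cc(C)nc3ccccc23)cc1` share one core and differ by methylsulfanyl in place of tert-butyl on an aromatic carbon. In an ADME assay on HEK293 cells (Homo sapiens) for cytotoxicity, with a stated time of 72 h (a lower number here means that less compound is needed, a higher number that more compound is needed for the effect), compound 1 gives only a limit of the assay, > 25000 nM. In this assay compound 2 gives 24000 nM. The step of an at least 1.0-fold lower number from compound 1 to compound 2 (0.01 log units; that floor lies within the scatter) is therefore only a floor, resting on (the limit of > 25000 nM in this assay, at which 2 of the 3 values shown sit). Compound 3 `Cc1cc(NC(=O)Nc2ccccc2C(C)(C)C)c2ccccc2n1` holds the same atoms as compound 1, but the difference between the two cores is not broken down here. In this assay compound 3 gives only a limit, > 25000 nM. Compound 4 `CSc1ccccc1NC(=O)Nc1cc(C)nc2ccccc12` differs from compound 3 by methylsulfanyl in place of tert-butyl on an aromatic carbon, the same kind of change, though here the group sits ortho to a large group rather than para to a large group. Since the earlier step of an at least 1.0-fold lower number from compound 1 to compound 2 (0.01 log units; that floor lies within the scatter) stayed within the scatter, compound 4 is expected to move by about a number no higher from compound 3 to compound 4 (the limit leaves the size open) in this assay. Compound 4 is thus estimated at 25000 nM, between 12000 nM and 50000 nM.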

Compound 4, half-maximal effective concentration: > 25000 nM
Compound 4 ended at the assay's limit (the forecaster's own chance of this, stated with the estimate: 60%); the middle value sits exactly at the limit.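

Compound 3 and compound 4 both stand at a limit in this assay, so no step can be read between them: the limit of > 25000 nM in this assay, at which 3 of the 4 values shown sit.

The compounds shown leave open whether methylsulfanyl in place of tert-butyl, ortho to a large group, changes the number at all.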